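Aryl variation on the shared core: antiproliferative read-out

The compounds below may be only part of what the source reports. "The series", "measured", "known", "first", "only" and "open" are said of these compounds alone.

Measured compounds:
- compound 1, `CCC1=C(O)c2c(oc(-c3ccc(C)cc3)cc2=O)C(CC)(CC)C1=O`: 0.08 uM
- compound 2, `CCC1=C(O)c2c(oc(-c3cccc(OC)c3)cc2=O)C(CC)(CC)C1=O`: 1.22 uM
- compound 3, `CCC1=C(O)c2c(oc(-c3ccccc3OC)cc2=O)C(CC)(CC)C1=O`: 3.26 uM

In a functional assay on KBVIN cells (Homo sapiens) for antiproliferative activity, read by sulforhodamine B assay, with a stated time of 3 days (on this read-out higher numbers stand for an effect only at larger amounts of compound and lower numbers for an effect already at smaller amounts), compound 3 gives the highest of the three numbers; the step of a 2.7-fold higher number from compound 2 to compound 3 (0.43 log units; beyond the scatter) is modest, while the step of a 41-fold higher number from compound 1 to compound 3 (1.61 log units; beyond the scatter) is large. Compound 1 has the lowest number of the set, and the step of a 15-fold higher number from compound 1 to compound 2 (1.18 log units; beyond the scatter) shows that moving from 4-methylphenyl to 3-methoxyphenyl already costs a good deal.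

Compound 4, `CCC1=C(O)c2c(oc(-c3ccc(O)c(C)c3C)cc2=O)C(CC)(CC)C1=O`, is not yet measured. Its change from compound 3 is 4-hydroxy-2,3-dimethylphenyl in place of 2-methoxyphenyl on an aromatic carbon. All three measured steps concern the same aryl position, so they bear on this step: the group with a substituent in the 4-position, compound 1, gives the lowest number, and the 2-methoxyphenyl of compound 3 the highest. Compound 4 carries a 4-hydroxy group together with two methyls, which is a substitution pattern not represented among compounds 1 to 3, so the direction is taken from compound 1 alone and the size is uncertain.

For compound 4 a lower number than for compound 3 is expected, a step of a 5.4-fold lower number from compound 3 to compound 4 (0.74 log units; beyond the scatter) in this assay, the estimate being 0.6 uM with a range of 0.1 uM to 3.5 uM.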

Compound 4, concentration for half-maximal effect: 2.75 uM
Beside the measured number, compound 4's estimate is 4.6-fold (0.66 log units) below it, and the stated range covers the measured number.
By their numbers in this assay, from the lowest: compound 1; then compound 2; then compounds 4 and 3 (each within the scatter of the next).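

In this assay the 4-hydroxy-2,3-dimethylphenyl group sits level with 2-methoxyphenyl (a 1.2-fold lower number from compound 3 to compound 4 (0.07 log units; within the scatter)), so a 4-hydroxy group on the aryl ring does not, in this combination, bring the number close to that of the 4-methylphenyl compound. Among the compounds shown here, the distance from that compound is large (a 34-fold higher number from compound 1 to compound 4 (1.54 log units; beyond the scatter)) and the distance from 3-methoxyphenyl is modest (a 2.3-fold higher number from compound 2 to compound 4 (0.35 log units; beyond the scatter)), which places the two groups numbered at the 2-position together at the high end of this set of four, with no compound here going against that grouping. No measured evidence is available to explain these differences.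

The shown compounds do not separate the contributions of the hydroxy group and the two methyl groups: 4-hydroxyphenyl, 2-methylphenyl and 2,3-dimethylphenyl are not among them, and the 2-substituent reading rests on only two compounds. On these data alone, it also remains open how this aryl position responds to other groups in the 4-position, such as ethyl, an amine or a carboxylic acid, and whether anything matches 4-methylphenyl.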